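This account rests on a few compounds, and the source may have more. Where it says the series, first, only, none or still open, it means among the compounds named here.

Working notes on the series.

Among the compounds with values here, compound 1 `O=C(Nc1ccc(Oc2ccnc3[nH]ccc23)cc1)c1nn(-c2ccc(Cl)c(F)c2)ccc1=O` is one of two compounds measured so far. In a functional assay on MCF7 cells (Homo sapiens) for cytotoxicity, read by MTT assay, with a stated time of 72 h (a higher number here means a weaker inhibitor, a lower number a stronger inhibitor), compound 1 gives 3110 nM. Within the data shown here, its only neighbour is compound 2 `O=C(Nc1ccc(Oc2ccnc3[nH]ccc23)cc1)c1nn(-c2ccc(Cl)c(C(F)(F)F)c2)ccc1=O`, which in this assay gives 6270 nM; the step of a 2.0-fold higher number from compound 1 to compound 2 (0.30 log units; within the scatter) sits within the scatter, so the two numbers are not separable and compound 1 cannot be set apart from compound 2 on this evidence.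

Compound 3 `O=C(Nc1ccc(Oc2ccnc3[nH]ccc23)c(F)c1)c1nn(-c2ccc(Cl)c(F)c2)ccc1=O` differs from compound 1 in one place: fluoro in place of hydrogen on an aromatic carbon. The shared core and the amide are unchanged. Among the measured compounds shown here, no measured step in this assay touches this position; the single step available, the change of fluoro to trifluoromethyl seen in a 2.0-fold higher number from compound 1 to compound 2 (0.30 log units; within the scatter), is at another ring and was itself within the scatter. There is therefore nothing in the measured numbers that points to a change of either direction from adding a single fluorine at this site.

Expectation: the step of a 1.0-fold lower number from compound 1 to compound 3 (0.02 log units; within the scatter) is estimated to stay within the scatter. Compound 3 is expected to give about 3000 nM in this assay, with a range from 1100 nM to 8500 nM.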

Compound 3, half-maximal inhibitory concentration: 11600 nM
Estimate against measurement, compound 3: 3.9-fold (0.59 log units) below; measured number above the stated range.
By their numbers in this assay, from the lowest: compounds 1, 2 and 3 (each within the scatter of the next, the first and the last beyond it).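

In this assay, within the data shown here, this aromatic carbon, ortho to a large group and meta to a large group, is the first place where a single change gives a step beyond the scatter (a 3.7-fold higher number from compound 1 to compound 3 (0.57 log units; beyond the scatter)). Fluoro in place of hydrogen, an addition of only one heavy atom, therefore moves compound 3 to the weaker side of compound 1, although the step is modest, whereas the only earlier step (a 2.0-fold higher number from compound 1 to compound 2 (0.30 log units; within the scatter)) stayed within the scatter and gave no direction. No measurement at hand accounts for this loss in the cytotoxicity read-out.

On these data alone, it remains open whether a step of this size and direction belongs to fluoro alone, or whether a chloro, a methoxy or an amine on the same aromatic carbon would give a similar number. Also open, as far as these compounds go, is whether the same fluoro would give a comparable step on compound 2, which carries trifluoromethyl in place of the fluoro of compound 1.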